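Methoxy for ethyl on the amide chain of compound 2

This account rests on a few compounds, and the source may have more. Where it says the series, first, only, none or still open, it means among the compounds named here.

Three amides built on a shared core have been measured in a functional assay (Sus scrofa) with sulfonylurea receptors; K-ATP channels (Homo sapiens) as the target; on this read-out lower numbers stand for an effect already at smaller amounts and higher numbers for an effect only at larger amounts of compound. Compound 1 `CCC(=O)Nc1c(C(O)(C(F)(F)F)C(F)(F)F)ccc2ccccc12` gives 8.91 nM in this assay. Compound 2 `CCCC(=O)Nc1c(C(O)(C(F)(F)F)C(F)(F)F)ccc2ccccc12` gives 708 nM, and compound 3 `CC(C)=CC(=O)Nc1c(C(O)(C(F)(F)F)C(F)(F)F)ccc2ccccc12` gives 550 nM. Compound 2 thus stands at the highest of the three numbers; its nearest neighbour is compound 3, with a 1.3-fold lower number from compound 2 to compound 3 (0.11 log units; within the scatter), while compound 1 lies far off, with a 79-fold higher number from compound 1 to compound 2 (1.90 log units; beyond the scatter). The other step to compound 1 is similar, a 62-fold higher number from compound 1 to compound 3 (1.79 log units; beyond the scatter).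

Compound 4 `COCC(=O)Nc1c(C(O)(C(F)(F)F)C(F)(F)F)ccc2ccccc12` has not yet been measured. It differs from compound 2 as follows: methoxy in place of ethyl on a saturated chain carbon bound to a carbonyl carbon. Of the measured steps, only the lengthening from compound 1 to compound 2 speaks to the chain beyond the carbonyl, and it was large; compound 3 shows that a second chain of comparable reach gives a number within the scatter of compound 2. For the measured compounds named here, no measured step exchanges a carbon for an oxygen in the chain, so the effect of the methoxy itself is unknown. Since compound 4 keeps a chain of the same reach as compound 2, compound 4 is estimated to give 350 nM in this assay, within 45 nM to 2500 nM, which is expected to mean a step of a 2.0-fold lower number from compound 2 to compound 4 (0.31 log units; beyond the scatter).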

Compound 4, half-maximal effective concentration: 204 nM
For compound 4 the middle estimate is 1.7-fold (0.23 log units) above the measured one; low and high end bracket the measured number.
By their numbers in this assay, from the lowest: compound 1; then compound 4; then compounds 3 and 2 (each within the scatter of the next).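

In this assay, exchanging a chain carbon for an oxygen at this place is not a silent change, although ethyl and methoxy both count 2 heavy atoms: the result is a 3.5-fold lower number from compound 2 to compound 4 (0.54 log units; beyond the scatter). The methoxymethyl chain also separates from the 2-methylprop-1-en-1-yl chain, with a 2.7-fold lower number from compound 3 to compound 4 (0.43 log units; beyond the scatter), so two chains that gave values within the scatter of each other no longer describe everything this position can do once methoxy, with its 1 hydrogen-bond acceptor, enters. Even so, this change closes only part of the gap to the ethyl amide, as a 23-fold higher number from compound 1 to compound 4 (1.36 log units; beyond the scatter) still marks a large step, and compound 1 keeps the lowest number of the four.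

Whether the difference comes from the oxygen itself cannot be said, as nothing at hand bears on the cause of this step.

Still open, as far as these compounds go, is whether a hydroxyl or a dimethylamino group on the same saturated chain carbon would follow methoxy or part from it. Also open, from the compounds shown here alone, is whether a longer ether, such as ethoxymethyl, would hold the number of compound 4 or move towards those of the longer carbon chains.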